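A Chloro Substituent on the Benzyl Arm

The source may report more compounds than this note shows. Statements on the series, on what has been measured and on what is new or still open speak of the compounds shown alone.

Among the measured compounds shown here, compound 2 `Cc1ccc(S(=O)(=O)Oc2ccccc2/C=C(\C#N)C(=O)Nc2nnc(Cc3ccccc3)s2)cc1` stands at the lower of the two numbers measured in an ADME assay on HEK-293T cells (Homo sapiens) for inhibition, read by CCK-8 assay, with a stated time of 48 h, tested at 20 uM (a lower number here means less inhibition of growth, a higher number more inhibition of growth at the concentration tested), at 15%, though the gap to its one neighbour is within the scatter. For the measured compounds named here, that neighbour is compound 1 `COc1ccc(Cc2nnc(NC(=O)/C(C#N)=C/c3ccccc3OS(=O)(=O)c3ccc(C)cc3)s2)cc1`, which in this assay gives 21%; the single step between them, a number 6 percentage points lower from compound 1 to compound 2 (within the scatter), came with hydrogen in place of methoxy on an aromatic carbon. Compound 3 `Cc1ccc(S(=O)(=O)Oc2ccccc2/C=C(\C#N)C(=O)Nc2nnc(Cc3ccc(Cl)cc3)s2)cc1` has not been measured. Its difference from compound 2 is chloro in place of hydrogen on an aromatic carbon. Going by the values given here, the one measured step bears on it only loosely: it concerned a substituent on the same ring of carbon only, and exchanging that substituent left the number in this assay within the scatter. Among the compounds with values here, with this as the only guide, compound 3 is expected to stay close to compound 2, a change of a number 3 percentage points higher from compound 2 to compound 3 (within the scatter) and no step beyond the scatter. The estimate for compound 3 in this assay is 18%, between 5% and 35%.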

Compound 3, percent growth inhibition at one concentration: 20%
Estimate against measurement, compound 3: 2 percentage points below, and the stated range covers the measured number.
By their numbers in this assay, from the lowest: compounds 2, 3 and 1 (each within the scatter of the next).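

In this assay, chloro at this position gives a number 5 percentage points higher from compound 2 to compound 3 (within the scatter) and, set against methoxy, a number 1 percentage points lower from compound 1 to compound 3 (within the scatter). The position on the benzyl arm has now carried hydrogen, methoxy and chloro, and all three exchanges stay within the scatter, so the flat reading seen for one exchange in the earlier pair also holds for chloro at the place para to a large group. No measured evidence available here bears on this result.

From the compounds shown here alone, whether an amine, a carboxylic acid or a longer chain at this position would move the number beyond the scatter remains open. So does whether a change elsewhere on the shared core, rather than on the benzyl arm, would shift growth inhibition at all.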